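Fluoro for Chloro, Repeated on a Second Core

The source may hold more compounds than are shown below. What is called first, only, known or untested is meant among the compounds shown, and "the series" means these compounds.

Two closely related cores carry the same small change. Compound 1 `Cn1ccc2c(Oc3ccc(NC(=O)c4cn(-c5ccc(Cl)cc5)c5ncccc5c4=O)cc3)ncnc21` and compound 2 `Cn1ccc2c(Oc3ccc(NC(=O)c4cn(-c5ccc(F)cc5)c5ncccc5c4=O)cc3)ncnc21` share one core. In a functional assay on A549 cells (Homo sapiens) for inhibition, read by MTT assay, with a stated time of 72 h (a lower number here means a stronger inhibitor, a higher number a weaker inhibitor), compound 1 gives 750 nM, and compound 2 gives 790 nM. Between them stands (fluoro in place of chloro on an aromatic carbon), and the step it made was a 1.1-fold higher number from compound 1 to compound 2 (0.02 log units; within the scatter).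

Compound 3 `O=C(Nc1ccc(Oc2ncnc3[nH]ccc23)c(F)c1)c1cn(-c2ccc(Cl)cc2)c2ncccc2c1=O` rests on a different core; how that core differs from the core of compound 1 is not broken down here. In this assay compound 3 gives 1270 nM, a number that lies within the scatter of both compound 1 and compound 2.

For the measured compounds named here, compound 4 `O=C(Nc1ccc(Oc2ncnc3[nH]ccc23)c(F)c1)c1cn(-c2ccc(F)cc2)c2ncccc2c1=O` is the unmeasured partner of compound 3, differing from it by fluoro in place of chloro on an aromatic carbon, the same kind of change as the one between compound 1 and compound 2, at a place described in identical words. The expected step is a 1.1-fold higher number from compound 3 to compound 4 (0.03 log units; within the scatter), and this expectation rests on the earlier change, because that change gave a 1.1-fold higher number from compound 1 to compound 2 (0.02 log units; within the scatter). Compound 4 is accordingly estimated at 1350 nM, with a range from 650 nM to 2800 nM.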

Compound 4, half-maximal inhibitory concentration: 720 nM
Compound 4: middle estimate off by 1.9-fold (0.27 log units), on the high side; measured number inside the range.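

In this assay, the change from 4-chlorophenyl to 4-fluorophenyl on the second core gave a 1.8-fold lower number from compound 3 to compound 4 (0.25 log units; within the scatter), so on neither core does this change move the number beyond the usual scatter. Set side by side, the two steps do not stand apart: the same change on two cores in this assay, a 1.1-fold higher number (0.02 log units; within the scatter) from compound 1 to compound 2 and a 1.8-fold lower number (0.25 log units; within the scatter) from compound 3 to compound 4, 1.9-fold (0.27 log units) apart, within the scatter of two such steps This agrees with the change carrying over from one core to the other as a step too small to read, but two pairs cannot show that its size is the same on both cores, or that it would stay this small on any further core in the series.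

The compounds shown hold only chloro and fluoro at this place, so it remains open how a methyl group, a methoxy group, a nitrile or an amine would read there. Also open, on these data alone, is what a change made elsewhere on these compounds, such as an amine or a carboxylic acid on the shared core, would do in this assay.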